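The source may hold more compounds than are shown below. What is called first, only, known or untested is meant among the compounds shown, and "the series" means these compounds.

Of the compounds shown here, three have been measured in a functional assay on NCI-H322M cells (Homo sapiens) for cytotoxicity, read by sulforhodamine B assay, with a stated time of 48 h; on this read-out lower numbers stand for stronger inhibition of growth and higher numbers for weaker inhibition of growth. Compound 1 `ClCc1ccc(Cn2cnc3c(Cl)ncnc32)cc1` gives 4160 nM, the second highest of the three numbers. Compound 3 `ClCc1cccc(Cn2cnc3c(Cl)nc(Cl)nc32)c1` gives 5120 nM, the nearest to it and within the scatter. Compound 2 `ClCc1ccccc1Cn1cnc2c(Cl)nc(Cl)nc21` gives 3270 nM, the furthest from compound 1 and still within the scatter. No ordering among the three can be read from these values.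

Compound 4 `ClCc1ccc(Cn2cnc3c(Cl)nc(Cl)nc32)cc1` has not yet been measured. It differs from compound 1 in one place: chloro in place of hydrogen on an aromatic carbon. For the measured compounds named here, no step between measured compounds matches this change directly. Compounds 2 and 3, whose cores already carry the chloro that enters here, give values that sit within the scatter of compound 1, so no step beyond the scatter is expected in this assay in either direction.

For compound 4 the expected value is 4000 nM, with a range of 2000 nM to 8000 nM, which amounts to an estimated step of a 1.0-fold lower number from compound 1 to compound 4 (0.02 log units; within the scatter).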

Compound 4, concentration for total growth inhibition: 25100 nM
For compound 4 the middle estimate is 6.3-fold (0.80 log units) below the measured one; measured number outside the range, above it.
By their numbers in this assay, from the lowest: compounds 2, 1 and 3 (each within the scatter of the next); then compound 4.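

In this assay, chloro in place of hydrogen on the aromatic carbon between two ring nitrogen atoms is not a neutral change on the core of compound 1, as it gives a 6.0-fold higher number from compound 1 to compound 4 (0.78 log units; beyond the scatter) towards weaker inhibition of growth. This chloro does not go with a high number in every compound: compound 2 gives 3270 nM and compound 3 gives 5120 nM while carrying it too, so the step cannot be taken as general for the series. Nothing available bears on the origin of this step.

From the compounds shown here alone, it remains open whether the same change gives a comparable step in the hydrogen counterparts of compounds 2 and 3. Going by these compounds, it is also open how an amine or a methoxy group at this position would compare with hydrogen and chloro.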